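Chloro to Methoxy on the Shared Core

The compounds below may be only part of what the source reports. "The series", "measured", "known", "first", "only" and "open" are said of these compounds alone.

Of the compounds shown here, three built on one shared core have been measured in an assay on isolated protein for inhibition of Fatty-acid amide hydrolase 1 (Rattus norvegicus); a lower number here means a stronger inhibitor, a higher number a weaker inhibitor. Compound 1 `O=C(CCCCCCc1ccccc1)c1nc(Cl)co1` gives 4 nM, compound 2 `CSc1coc(C(=O)CCCCCCc2ccccc2)n1` gives 29 nM, and compound 3 `CNC(=O)c1coc(C(=O)CCCCCCc2ccccc2)n1` gives 1.8 nM. Among these three numbers compound 1 stands second highest, with compound 3 nearest to it and compound 2 furthest away.

Compound 4 `COc1coc(C(=O)CCCCCCc2ccccc2)n1` has not yet been measured. It differs from compound 1 in a single place: methoxy in place of chloro on an aromatic carbon.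

For the measured compounds named here, two measured steps bear on this change, since both also replace the chloro on the same aromatic carbon. Putting methylsulfanyl there gave a 7.3-fold higher number from compound 1 to compound 2 (0.86 log units; beyond the scatter), while putting methylcarbamoyl there gave a 2.2-fold lower number from compound 1 to compound 3 (0.35 log units; beyond the scatter); the gap between those two outcomes is the large step of a 16-fold lower number from compound 2 to compound 3 (1.21 log units; beyond the scatter). One replacement thus weakened inhibition modestly and the other strengthened it modestly, so the same position tolerates change in either direction. Going by the values given here, with no closer precedent for methoxy, the expectation is a step only a little beyond the scatter, leaning toward a weaker inhibitor, namely an expected 2.5-fold higher number from compound 1 to compound 4 (0.40 log units; beyond the scatter). The estimate for compound 4 in this assay is therefore 10 nM, with a range from 3 nM to 40 nM.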

Compound 4, inhibition constant: 740 nM
For compound 4 the middle estimate is 74-fold (1.87 log units) below the measured one; the whole stated range lies below it.
By their numbers in this assay, from the lowest: compound 3; then compound 1; then compound 2; then compound 4.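

In this assay, this carbon proves far less forgiving than the first three compounds suggested: swapping chloro for methoxy gives a 190-fold higher number from compound 1 to compound 4 (2.27 log units; beyond the scatter), a bigger step than any among those three. Methoxy and methylsulfanyl differ only in having oxygen or sulfur as the atom attached to the ring carbon, yet that single exchange gives a 26-fold higher number from compound 2 to compound 4 (1.41 log units; beyond the scatter), so the choice of this one atom matters greatly among the groups shown, and the widest gap of the four compounds is now a 410-fold higher number from compound 3 to compound 4 (2.61 log units; beyond the scatter). Nothing available here accounts for the size of these steps.

The compounds shown leave open whether the loss follows the oxygen attached to the ring or the methoxy group as a whole, and a hydroxyl, an ethoxy or a dimethylamino group on the same carbon would help separate the two. Going by these compounds, it is also open how a fluoro or bromo group would compare with the chloro of compound 1, and whether a simple carboxylic acid would stay close to the methylcarbamoyl of compound 3.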